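A few compounds are considered here, and "the series" means these few. Any claim that something is new, unique, unknown or untested is made for them only; others in the source may bear on it.

Measured so far in a physicochemical assay for solubility, read by turbidimetry, measured as kinetic solubility, at pH 7.4; a lower number here means a less soluble compound, a higher number a more soluble compound:
Compound 1 `Cc1ccnc(N2C(=O)CSC2c2cccc(C(=O)NCCCCn3cccn3)c2)c1` (50000 nM)
Compound 2 `O=C(NCCCCc1ccccc1)c1cccc(C2SCC(=O)N2c2cccc(-c3c[nH]nn3)c2)c1` (20000 nM)
Compound 3 `O=C(NCCCCn1cccn1)c1cccc(C2SCC(=O)N2c2cc(F)ccn2)c1` (50000 nM)

Compound 2 (20000 nM) has the lowest number of the three, and the gaps to compound 1 and compound 3 both lie beyond the scatter. The next compound is compound 4 `O=C(NCCCCc1ccccc1)c1cccc(C2SCC(=O)N2c2ccc(C3CC3)cc2)c1`, still unmeasured. It differs from compound 2 on an amide-type nitrogen in a ring: a group of 9 heavy atoms (9 carbon; one three-membered non-aromatic ring of carbon only, one six-membered aromatic ring of carbon only) in place of a group of 11 heavy atoms (8 carbon, 3 nitrogen; one five-membered aromatic ring with 3 hetero atoms, one six-membered aromatic ring of carbon only), on an amide-type nitrogen in a ring. Going by the values given here, one measured step touches a group at that nitrogen (no change at the digits printed from compound 1 to compound 3 (within the scatter)), but it is only fluoro in place of methyl on an aromatic carbon. Among the compounds with values here, it therefore gives little guidance for an exchange of this size, and no measured step covers one. Going by the counted change alone, a moderate move to a lower number is expected in this assay, starting from compound 2 (20000 nM), with low confidence. The expected step is a 2.5-fold lower number from compound 2 to compound 4 (0.40 log units; beyond the scatter) as estimated here. The estimate for compound 4 is 8000 nM, with an expected range of 2500 nM to 25000 nM for the measurement.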

Compound 4, solubility: 2000 nM
Compound 4: middle estimate off by 4.0-fold (0.60 log units), on the high side; measured number below the stated range.
By their numbers in this assay, from the lowest: compound 4; then compound 2; then compounds 1 and 3 (each within the scatter of the next).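

In this assay, the exchange on the amide-type nitrogen in a ring gives a 10-fold lower number from compound 2 to compound 4 (1.00 log units; beyond the scatter), so this position can carry a large step, which the small fluoro-for-methyl change, no change at the digits printed from compound 1 to compound 3 (within the scatter), did not reveal. The group that leaves counts 1 hydrogen-bond donor and 2 hydrogen-bond acceptors, whereas 4-cyclopropylphenyl counts 0 of each, but this count alone does not tie the step to any one feature. Nothing measured here bears on the cause of the step.

The compounds shown leave open whether the step follows from the loss of the five-membered aromatic ring with 3 hetero atoms, the gain of the cyclopropyl ring, or both together. Also open, as far as these compounds go, is how an amine or a carboxylic acid on the six-membered aromatic ring at this position would read in this assay.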